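Swapping the Bicyclic Amide Head on a Sulfonamide Scaffold

This account rests on a few compounds, and the source may have more. Where it says the series, first, only, none or still open, it means among the compounds named here.

Three compounds have numbers in an assay for inhibition of Nicotinamide phosphoribosyltransferase (Homo sapiens), read by mass spectrometry, with stated times of 15 min and 30 min; a lower number here means a stronger inhibitor, a higher number a weaker inhibitor. Compound 1 `O=C(NCc1ccc(S(=O)(=O)c2ccccc2)cc1)c1nc2ccncc2s1` gives 210 nM, compound 2 `O=C(NCc1ccc(S(=O)(=O)c2ccccc2)cc1)c1ccc2nccn2c1` gives 18 nM, and compound 3 `O=C(NCc1ccc(S(=O)(=O)N2CCCCC2)cc1)c1cc2cnccc2s1` gives 150 nM, which places compound 3 second highest of the three, close to compound 1 and well apart from compound 2. Compound 4 `O=C(NCc1ccc(S(=O)(=O)N2CCCCC2)cc1)c1cc2ccncc2[nH]1` has not been measured. It differs from compound 3 in one place: a group of 9 heavy atoms (7 carbon, 2 nitrogen; one five-membered aromatic ring with 1 hetero atom, one six-membered aromatic ring with 1 hetero atom) in place of a group of 9 heavy atoms (7 carbon, 1 nitrogen, 1 sulfur; one five-membered aromatic ring with 1 hetero atom, one six-membered aromatic ring with 1 hetero atom), on a carbonyl carbon. Going by the values given here, the only measured step of a similar kind is a 12-fold lower number from compound 1 to compound 2 (1.07 log units; beyond the scatter), where a sulfur-containing bicyclic group on the carbonyl carbon was likewise replaced by an all-carbon-and-nitrogen bicyclic group, and the number fell markedly. Among the compounds with values here, no step exists between compounds carrying the same sulfonamide as compound 3, so the transfer is uncertain. On that single precedent, a step toward a lower number beyond the scatter is expected, though smaller than the measured one, and compound 4 is expected to reach 60 nM in this assay, with a range from 20 nM to 200 nM, an expected step of a 2.5-fold lower number from compound 3 to compound 4 (0.40 log units; beyond the scatter).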

Compound 4, half-maximal inhibitory concentration: 1000 nM
Beside the measured number, compound 4's estimate is 17-fold (1.22 log units) below it; measured number above the stated range.
By their numbers in this assay, from the lowest: compound 2; then compounds 3 and 1 (each within the scatter of the next); then compound 4.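

In this assay, exchanging the sulfur-containing group on the carbonyl carbon for the all-carbon-and-nitrogen group gives a 6.7-fold higher number from compound 3 to compound 4 (0.82 log units; beyond the scatter), with the entering group carrying 1 hydrogen-bond donor and 1 hydrogen-bond acceptor where the leaving group carried 0 and 2. This runs opposite to a 12-fold lower number from compound 1 to compound 2 (1.07 log units; beyond the scatter), so among the compounds shown, losing sulfur from the group at this position has no single direction, and the identity of the incoming group matters. No measurement offered here accounts for the difference between these two steps.

On these data alone, it remains open how the group carried by compound 2 would behave on the sulfonamide of compound 3. As far as these compounds go, it is also open whether a methyl group in place of the donor hydrogen of the entering group would bring the number back toward that of compound 3.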